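Ceramide-type glycolipids: extending the primary hydroxyl of compound 1

The source may hold more compounds than are shown below. What is called first, only, known or untested is meant among the compounds shown, and "the series" means these compounds.

Measured so far:
compound 1 `CCCCCCCC/C=C\CCCCCCCC(=O)N[C@H]1[C@@H](OCCCCCCCC)O[C@H](CO)[C@@H](O)[C@@H]1O`: 13.3 uM
compound 2 `CCCCC(=O)N[C@H]1[C@@H](OCCc2ccccc2)O[C@H](COCC(CO)(CO)COS(=O)(=O)O)[C@@H](O)[C@@H]1O`: 6.7 uM

In a functional assay on U-373MG ATCC cells (Homo sapiens), read by thymidine incorporation (a lower number here means a stronger inhibitor, a higher number a weaker inhibitor), compound 1 gives 13.3 uM and compound 2 gives 6.7 uM; the two numbers lie within the scatter of each other, so neither compound stands apart from the other. Compound 3 `CCCCCCCC/C=C\CCCCCCCC(=O)N[C@H]1[C@@H](OCCCCCCCC)O[C@H](COCC(CO)(CO)CO)[C@@H](O)[C@@H]1O` is not yet measured. It differs from compound 1 in one place: 3-hydroxy-2,2-bis(hydroxymethyl)propyl in place of hydrogen on an oxygen on a saturated carbon. Compound 2 carries a related branched arm on the same oxygen, capped with a sulfate, but it also differs from compound 1 in the acyl chain and the aglycone, so no single-change step can be read from the two measured numbers. With compound 2 at 6.7 uM as the only hint that such an arm is tolerated, the step of a 1.5-fold lower number from compound 1 to compound 3 (0.17 log units; within the scatter) is expected to stay within the scatter, leaning if anything toward a lower number. Compound 3 is therefore expected to give about 9 uM in this assay, with a likely range from 3 uM to 30 uM.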

Compound 3, concentration for 50% inhibition: 20.6 uM
The estimate for compound 3 lay 2.3-fold (0.36 log units) below the measured number, within the range that was stated.
By their numbers in this assay, from the lowest: compounds 2, 1 and 3 (each within the scatter of the next, the first and the last beyond it).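

In this assay, among the compounds shown here, putting 3-hydroxy-2,2-bis(hydroxymethyl)propyl in place of hydrogen on this oxygen gives a 1.5-fold higher number from compound 1 to compound 3 (0.19 log units; within the scatter), the first single-change reading at this position. The shared core with its oleoyl-type acyl chain and octyl aglycone therefore keeps its activity in this assay with this uncharged, branched arm in place, and the step shows no gain or loss beyond the scatter. No measurement on hand accounts for this outcome.

Compound 2 differs from compound 3 in more than one place, so the contribution of its sulfate cap cannot be read from the steps available. Open too, going by these compounds, is whether an amine or a carboxylic acid at the end of the arm, or a longer chain between this oxygen and the branch point, would move the number beyond the scatter.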